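The source may report more compounds than this note shows. Statements on the series, on what has been measured and on what is new or still open speak of the compounds shown alone.

Among the compounds with values here, compound 2 `CC(C)c1noc(CN2CCC(O[C@H]3CC[C@H](Oc4cnc(S(C)(=O)=O)cn4)CC3)CC2)n1` is one of two compounds measured in a functional assay on isolated protein for agonist activity at Glucose-dependent insulinotropic receptor (Rattus norvegicus), read by HTRF and cAMP accumulation; on this read-out lower numbers stand for smaller maximal responses and higher numbers for larger maximal responses. In this assay compound 2 gives 115%. Within the data shown here, its only companion is compound 1 `CC(C)(C)OC(=O)N1CCC(O[C@H]2CC[C@H](Oc3cnc(S(C)(=O)=O)cn3)CC2)CC1`, which in this assay gives 110%; the two sit within the scatter of each other, as the step of a number 5 percentage points higher from compound 1 to compound 2 (within the scatter) shows, so neither can be called the more active of the pair.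

Compound 3 `CC(F)Cc1nc(CN2CCC(O[C@H]3CC[C@H](Oc4cnc(S(C)(=O)=O)cn4)CC3)CC2)no1` differs from compound 2 in one place: 5-(2-fluoropropyl)-1,2,4-oxadiazol-3-yl in place of 3-isopropyl-1,2,4-oxadiazol-5-yl on a saturated chain carbon bound to an amine nitrogen in a ring. Among the measured compounds shown here, the only measured step that bears on this position is the swap from compound 1 to compound 2, which replaced the whole group on the amine nitrogen and moved the maximal response by a number 5 percentage points higher from compound 1 to compound 2 (within the scatter), within the scatter. Since a larger exchange there left the response unchanged, a rearranged oxadiazole is expected to do the same, and the step of a number 5 percentage points lower from compound 2 to compound 3 (within the scatter) is estimated to stay within the scatter. For compound 3 the expected value in this assay is therefore 110%, with a range from 95% to 125%.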

Compound 3, largest response reached (Emax), in percent of the reference or control that the assay uses: 114%
For compound 3 the middle estimate is 4 percentage points below the measured one, within the range that was stated.
By their numbers in this assay, from the lowest: compounds 1, 3 and 2 (each within the scatter of the next).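

Exchanging 3-isopropyl-1,2,4-oxadiazol-5-yl for 5-(2-fluoropropyl)-1,2,4-oxadiazol-3-yl gives, in this assay, a number 1 percentage points lower from compound 2 to compound 3 (within the scatter), so two differently built oxadiazole groups now cannot be told apart at this position. Compared with tert-butoxycarbonyl on the amine nitrogen in the ring, the new group gives a number 4 percentage points higher from compound 1 to compound 3 (within the scatter), which places all three groups seen here within the scatter of one another and shows no preference among them on maximal response. Nothing available explains this similarity.

The compounds shown leave open whether a group of a different kind, such as a carboxylic acid or a primary amine at the end of a longer chain, would give a similar maximal response. They also do not show how far this tolerance extends, since every group here is either an oxadiazole or tert-butoxycarbonyl.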